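The source may hold more compounds than are shown below. What is called first, only, known or untested is meant among the compounds shown, and "the series" means these compounds.

Compound 2 `COc1cccc(CN2Cc3c(NC(=O)c4ccccc4)n[nH]c3C2(C)C)c1` and compound 1 `CC1(C)c2[nH]nc(NC(=O)c3ccccc3)c2CN1Cc1ccccc1` share one core and differ only at a single aromatic carbon. In an assay on Sf21 cells for inhibition of high affinity nerve growth factor receptor (Homo sapiens), read by HTRF, with a stated time of 30 min, in the presence of a further agent that is not named here (a lower number here means a stronger inhibitor, a higher number a weaker inhibitor), compound 1 gives 1240 nM, and compound 2 gives 1120 nM; the two numbers lie within the usual scatter of each other, as the step of a 1.1-fold lower number from compound 1 to compound 2 (0.04 log units; within the scatter) shows. Compound 3 `CC1(C)c2[nH]nc(NC(=O)c3ccccc3)c2CN1Cc1cccc(C#N)c1` carries the change (cyano in place of methoxy on an aromatic carbon). Among the measured compounds shown here, the one measured step that bears on this position did not move the number beyond the scatter, so compound 3 is expected to behave much like compound 2, with an estimated step of a 1.0-fold lower number from compound 2 to compound 3 (0.01 log units; within the scatter). The expected value for compound 3 in this assay is 1100 nM, within a range from 500 nM to 2500 nM.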

Compound 3, half-maximal inhibitory concentration: 980 nM
For compound 3 the middle estimate is 1.1-fold (0.05 log units) above the measured one; measured number inside the range.
By their numbers in this assay, from the lowest: compounds 3, 2 and 1 (each within the scatter of the next).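

Cyano in place of methoxy gives a 1.1-fold lower number from compound 2 to compound 3 (0.06 log units; within the scatter) in this assay and cyano in place of hydrogen gives a 1.3-fold lower number from compound 1 to compound 3 (0.10 log units; within the scatter) at this same place on the ring. This carbon, meta to a large group, has now carried a second group, and in this assay neither methoxy nor cyano stands apart from hydrogen or from each other. No evidence is available on why these numbers stay so close. Still open, from the compounds shown here alone, is whether an amine, a carboxylic acid or a longer chain on this carbon would move the number beyond the scatter.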